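Amide in place of ester at the carbonyl of the core

A few compounds are considered here, and "the series" means these few. Any claim that something is new, unique, unknown or untested is made for them only; others in the source may bear on it.

Measured so far:
compound 1 `C#CCCOC(=O)c1ccc(C(CC)(CC)c2ccc(OCCC(O)(CC)CC)c(C)c2)n1CC`, > 50000 nM
compound 2 `CCC(C)C(NC(=O)c1ccc(C(CC)(CC)c2ccc(OCCC(O)(CC)CC)c(C)c2)n1CC)C(=O)O`, 11300 nM

In a functional assay on MCF7 cells (Homo sapiens) for antiproliferative activity, read by MTT assay, with a stated time of 48 h (a higher number here means a weaker inhibitor, a lower number a stronger inhibitor), compound 1 gives only a limit, > 50000 nM, namely (the limit of > 50000 nM in this assay, at which 1 of the 2 values shown sits). Compound 2 gives 11300 nM in this assay, and the step of an at least 4.4-fold lower number from compound 1 to compound 2 (0.64 log units; beyond the scatter) is the only measured one that bears on the change to compound 3 `CCn1c(C(=O)N(C)CCO)ccc1C(CC)(CC)c1ccc(OCCC(O)(CC)CC)c(C)c1`, which differs from compound 1 as (2-hydroxyethyl)(methyl)amino in place of (but-3-yn-1-yl)oxy on a carbonyl carbon. A step in the same direction is expected, an at least 3.3-fold lower number from compound 1 to compound 3 (0.52 log units; beyond the scatter). Compound 3 is therefore estimated at 15000 nM, within 5000 nM to 50000 nM.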

Compound 3, half-maximal inhibitory concentration: 2870 nM
For compound 3 the middle estimate is 5.2-fold (0.72 log units) above the measured one, and the stated range ends above it.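

In this assay, the amides at this carbonyl carbon are not equivalent: (2-hydroxyethyl)(methyl)amino in place of (1-carboxy-2-methylbutyl)amino gives a 3.9-fold lower number from compound 2 to compound 3 (0.60 log units; beyond the scatter). Replacing the (but-3-yn-1-yl)oxy ester directly gives an at least 17-fold lower number from compound 1 to compound 3 (1.24 log units; beyond the scatter). The size of that second step is a minimum, since the value for compound 1 is a limit and not a number: the limit of > 50000 nM in this assay, at which 1 of the 3 values shown sits.

Whether the hydroxyl or the methyl on the amide nitrogen accounts for the difference stays open, as compound 2 and compound 3 differ in both. A dimethylamino group or a 3-hydroxypropyl chain on the amide nitrogen would help separate the two.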